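Fluoro in Place of Hydrogen on a Limit-Bound Compound

The source may hold more compounds than are shown below. What is called first, only, known or untested is meant among the compounds shown, and "the series" means these compounds.

Compound 2 `CC(C)n1cc2c(Cl)nc(NC(=O)c3ccccc3)nc2n1` sits at a limit in a functional assay on CHO cells for antagonist activity at adenosine receptor A2b (Homo sapiens), read by 33P incorporation, with a stated time of 20 min, in the presence of a further agent that is not named here; on this read-out higher numbers stand for weaker inhibition and lower numbers for stronger inhibition: it gives > 20000 nM, a limit of the assay and not a number. Compound 1 `CC(C)(C)Cn1cc2c(Cl)nc(NC(=O)c3ccccc3)nc2n1` likewise gives only a limit, >= 10000 nM. Compound 3 `CC(C)(C)Cn1cc2c(Cl)nc(NC(=O)c3ccc(C(F)(F)F)cc3)nc2n1` also gives only a limit, > 20000 nM. The step that the two limits leave unreadable from compound 1 to compound 2 and the step that the two limits leave unreadable from compound 1 to compound 3 are therefore unreadable, as the limit of > 20000 nM in this assay, at which 2 of the 3 values shown sit, and the limit of >= 10000 nM in this assay, at which 1 of the 3 values shown sits, show. Compound 4 `CC(C)n1cc2c(Cl)nc(NC(=O)c3ccc(F)cc3)nc2n1` differs from compound 2 by fluoro in place of hydrogen on an aromatic carbon. Neither measured step bears readably on this change, and compound 3 carries a related change yet still ends at a limit. Compound 4 is therefore expected to stay near the limit, with an estimated step that the limit leaves unreadable from compound 2 to compound 4 no larger than the scatter. Compound 4 in this assay is estimated at 25000 nM, between 10000 nM and 60000 nM.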

Compound 4, inhibition constant: > 20000 nM
Compound 4 gave a limit, no number; the forecaster's own chance of this, stated with the estimate: 85%; the middle value lies beyond the limit too.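

Compound 2 and compound 4 both end at a limit of the assay and not at a number, so no step between them can be read: the limit of > 20000 nM in this assay, at which 3 of the 4 values shown sit.

The compounds shown leave open whether fluoro in place of hydrogen changes inhibition in this assay at all, and none of them gives a number there.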